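Working notes: side chain exchange from compound 2 to compound 3

This account rests on a few compounds, and the source may have more. Where it says the series, first, only, none or still open, it means among the compounds named here.

Measured so far:
compound 1 `CC(=O)COc1cc(=O)oc2cc(OCc3cccc(Cl)c3)ccc12`: 22%
compound 2 `O=C(COc1cc(=O)oc2cc(OCc3cccc(Cl)c3)ccc12)N1CCCCC1`: 9%

For the measured compounds named here, in an assay on isolated protein (strain Sprague-Dawley) for inhibition of Amine oxidase [flavin-containing] A (Rattus norvegicus), read by spectrophotometry, with a stated time of 5 min, tested at 10 uM (a lower number here means less inhibition, a higher number more inhibition at the concentration tested (going by the name of the read-out)), compound 1 gives 22%, while compound 2 gives 9%, the lowest of the two numbers; the single step, a number 13 percentage points lower from compound 1 to compound 2 (beyond the scatter), lies beyond the scatter. Compound 3 `CCOC(=O)Nc1cc(=O)oc2cc(OCc3cccc(Cl)c3)ccc12` differs from compound 2 by (ethoxycarbonyl)amino in place of ((piperidin-1-yl)carbonyl)methoxy on an aromatic carbon. Going by the values given here, no measured step concerns this place or this exchange, so the one step between compound 1 and compound 2 gives only weak guidance. Compound 3 is therefore expected to stay near the low end of the series, with an expected step of a number 6 percentage points higher from compound 2 to compound 3 (within the scatter) hardly beyond the scatter. The estimate for compound 3 is 15%, between 0% and 40%.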

Compound 3, a percentage reported as inhibition, at one concentration (the size of the read-out at that concentration, not a potency): 21%
Compound 3: the middle estimate sits 6 percentage points below what was measured; measured number inside the range.
By their numbers in this assay, from the lowest: compound 2; then compounds 3 and 1 (each within the scatter of the next).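

At this place, opposite the ring oxygen, this assay gives a number 12 percentage points higher from compound 2 to compound 3 (beyond the scatter) with (ethoxycarbonyl)amino in place of ((piperidin-1-yl)carbonyl)methoxy, so the low number of compound 2 does not carry over to this group. In the same assay, a number 1 percentage points lower from compound 1 to compound 3 (within the scatter) with (ethoxycarbonyl)amino in place of 2-oxopropoxy, so these two groups cannot be separated here. Nothing available accounts for these numbers.

Still open, on these data alone, is how a plain amine, a carboxylic acid or a longer chain at this place would compare with these groups.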